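The compounds below may be only part of what the source reports. "The series", "measured", "known", "first", "only" and "open" are said of these compounds alone.

In a functional assay on ASPC1 cells (Homo sapiens) for cytotoxicity (a higher number here means a weaker inhibitor, a lower number a stronger inhibitor), compound 2 `O=[N+]([O-])c1ccc(NC(CO)CO)c([N+](=O)[O-])c1` gives only a limit of the assay, > 100000 nM, and not a number. Compound 1 `O=[N+]([O-])c1ccccc1NC(CO)CO` in this assay also reaches only the limit of > 100000 nM. Compound 3 `O=[N+]([O-])c1cc(C(F)(F)F)ccc1NC(CO)CO` in this assay likewise stops at the limit of > 100000 nM. All three values thus sit at one and the same limit, (the limit of > 100000 nM in this assay, at which 3 of the 3 values shown sit), so no order among these compounds can be read, and compound 2 can only be placed at that limit together with the others.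

Compound 4 `O=[N+]([O-])c1ccc(NC(CO)CO)c(C(F)(F)F)c1` differs from compound 2 in one place: trifluoromethyl in place of nitro on an aromatic carbon. The measured step that comes closest is the same swap at another aromatic carbon, a step that the two limits leave unreadable from compound 2 to compound 3. The steps a step that the two limits leave unreadable from compound 1 to compound 2 and a step that the two limits leave unreadable from compound 1 to compound 3 are equally unreadable, since each runs between two limits. Among the measured compounds shown here, no size and no direction can therefore be drawn from the measured steps for the change in this assay, and the only guide is that every compound of this set so far has stayed at the limit.

Compound 4 is accordingly expected to give about 100000 nM in this assay, within the range 30000 nM to 300000 nM, and most probably again only as a limit. The step from compound 2 to compound 4 is estimated as a number no higher from compound 2 to compound 4 (the limit leaves the size open), which is nothing beyond the scatter.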

Compound 4, half-maximal inhibitory concentration: > 100000 nM
Compound 4: a limit, no number; the forecaster's own chance of this, stated with the estimate: 85%; the middle value lies on the limit itself.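

In this assay compound 4 gives > 100000 nM, which is a limit and not a number. No size or direction can be read for the change from compound 2 to compound 4, since both values are limits: the limit of > 100000 nM in this assay, at which 4 of the 4 values shown sit.

The compounds shown leave open whether trifluoromethyl in place of nitro changes the cytotoxicity at all, and in which direction.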